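Replacing a Furanylmethyl Amine Substituent with a Carbamoyloxy-Phenylethyl Group

The source may report more compounds than this note shows. Statements on the series, on what has been measured and on what is new or still open speak of the compounds shown alone.

Compound 1, `c1ccc(CNCC2CCN(CCCc3c[nH]c4ccc(-n5cnnc5)cc34)CC2)cc1`: 5.6 nM
Compound 2, `c1cc(CNC2CCN(CCCc3c[nH]c4ccc(-n5cnnc5)cc34)CC2)co1`: 7.1 nM

Both compounds were tested in an assay on CHO cells for agonist activity at 5-hydroxytryptamine receptor 1D (Homo sapiens), read by GTPgammaS binding; a lower number here means that less compound is needed, a higher number that more compound is needed for the effect. Going by the values given here, compound 2 stands highest of the two numbers, but its only neighbour lies within the scatter: a 1.3-fold higher number from compound 1 to compound 2 (0.10 log units; within the scatter). That step exchanged one arylmethyl amine substituent for another and moved nothing beyond the noise.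

Compound 3, `NC(=O)OC[C@H](NC1CCN(CCCc2c[nH]c3ccc(-n4cnnc4)cc23)CC1)c1ccccc1`, differs from compound 2 by 2-(carbamoyloxy)-1-phenylethyl in place of (furan-3-yl)methyl on an amine nitrogen. Among the compounds with values here, the entering group is larger and carries a carbamate, and no measured step tests such a substituent; the only step that bears on a change at this amine nitrogen is the one between compound 1 and compound 2, which was small. The expected step is therefore a 1.1-fold higher number from compound 2 to compound 3 (0.05 log units; within the scatter), with a wide uncertainty because a 1.3-fold higher number from compound 1 to compound 2 (0.10 log units; within the scatter) says little about a group of this kind. Compound 3 is estimated at 8 nM, with a range from 2.5 nM to 30 nM.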

Compound 3, half-maximal effective concentration: 9.3 nM
Beside the measured number, compound 3's estimate is 1.2-fold (0.07 log units) below it; low and high end bracket the measured number.
By their numbers in this assay, from the lowest: compounds 1, 2 and 3 (each within the scatter of the next).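

In this assay, putting 2-(carbamoyloxy)-1-phenylethyl in place of (furan-3-yl)methyl on the amine nitrogen gives a 1.3-fold higher number from compound 2 to compound 3 (0.12 log units; within the scatter). The earlier compounds shown here showed only arylmethyl groups on an amine, whereas this result shows that the number stays within the scatter with a much larger substituent that carries a carbamate, a hydrogen-bond donor and a defined stereocentre. Nothing available here accounts for this outcome.

The compounds shown do not separate the contribution of the carbamate from that of the phenyl ring, a question that a plain 1-phenylethyl or a 2-hydroxy-1-phenylethyl group on the same nitrogen could address. They also leave open how the opposite configuration at the stereocentre would read, and whether a carboxylic acid in place of the carbamate would keep the number within the scatter.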